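From 3-bromophenyl to (4-bromophenyl)carbonyl at the assay limit

A few compounds are considered here, and "the series" means these few. Any claim that something is new, unique, unknown or untested is made for them only; others in the source may bear on it.

In a functional assay on HT-29 cells (Homo sapiens) for inhibition, read by MTT assay, with a stated time of 72 h (a higher number here means a weaker inhibitor, a lower number a stronger inhibitor), compound 1 (`C=C[C@]1(C)C[C@@H](OC(=O)CNC(=O)Nc2ccc(OC)cc2)[C@]2(C)[C@H](C)CC[C@]3(CCC(=O)[C@H]32)[C@@H](C)[C@@H]1O`) gives > 10000 nM, which is a limit and not a number. Compound 2 (`C=C[C@]1(C)C[C@@H](OC(=O)CNC(=O)Nc2cccc(Br)c2)[C@]2(C)[C@H](C)CC[C@]3(CCC(=O)[C@H]32)[C@@H](C)[C@@H]1O`) gives > 10000 nM, which is also a limit. Compound 2 therefore has no numerical value. Compound 3 (`C=C[C@]1(C)C[C@@H](OC(=O)CNC(=O)NC(=O)c2ccc(Br)cc2)[C@]2(C)[C@H](C)CC[C@]3(CCC(=O)[C@H]32)[C@@H](C)[C@@H]1O`) differs from compound 2 as follows: (4-bromophenyl)carbonyl in place of 3-bromophenyl on an amide-type nitrogen. In short, (4-bromophenyl)carbonyl stands in place of 3-bromophenyl on an amide-type nitrogen. Among the compounds with values here, the only measured step that bears on this change is a step that the two limits leave unreadable from compound 1 to compound 2, so it offers no size to carry over. Within the data shown here, the sole guide is the limit of > 10000 nM in this assay, at which 2 of the 2 values shown sit. A step beyond the usual scatter is therefore not expected in this assay, and no direction can be favoured. The estimated change is a step that the limit leaves unreadable from compound 2 to compound 3. For compound 3, the expected value is 15000 nM, with an estimated range from 6000 nM to 40000 nM.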

Compound 3, half-maximal inhibitory concentration: > 10000 nM
Compound 3 gave a limit, no number (the forecaster's own chance of this, stated with the estimate: 80%); the middle value does not contradict the limit.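

In this assay compound 3 gives only a limit, as do compound 1 and compound 2, so no step among these three compounds can be read. The compounds shown leave open whether any of these groups on the amide-type nitrogen changes inhibition, because all three rest on one result: the limit of > 10000 nM in this assay, at which 3 of the 3 values shown sit.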